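A few compounds are considered here, and "the series" means these few. Any claim that something is new, unique, unknown or untested is made for them only; others in the source may bear on it.

Among the compounds with values here, in a physicochemical assay for metabolic stability, at 30 degrees C, at pH 6.5 (a higher number here means that the compound lasts longer, a lower number that the compound disappears faster), compound 1 `Nc1ncnc2c1ncn2[C@@H]1O[C@@H]2CO[P@@](=O)(OCc3ccccc3)O[C@H]2[C@H]1O` gives 3 h, the lower of the two numbers so far, and compound 2 `Nc1ncnc2c1ncn2[C@@H]1O[C@@H]2CO[P@](=O)(OCc3ccccc3)O[C@H]2[C@H]1O` gives 9.5 h. Compound 3 `Nc1ncnc2c1ncn2[C@@H]1O[C@@H]2CO[P@@](=O)(OCc3ccccc3[N+](=O)[O-])O[C@H]2[C@H]1O` keeps the core of compound 1 and turns benzyl into 2-nitrobenzyl: nitro in place of hydrogen on an aromatic carbon. Within the data shown here, the only measured step, a 3.2-fold higher number from compound 1 to compound 2 (0.50 log units; beyond the scatter), comes with the fact that compounds 1 and 2 differ only in the configuration as drawn, so it does not cover a change of this kind and gives only a rough idea of how far numbers can move. No step beyond the scatter is expected in this assay, in either direction, and the estimated step is a 1.2-fold lower number from compound 1 to compound 3 (0.08 log units; within the scatter). The expected value for compound 3 is 2.5 h, within a range of 0.9 h to 7 h.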

Compound 3, half-life: 3 h
Compound 3: the middle estimate sits 1.2-fold (0.08 log units) below what was measured; the range from low to high includes it.
By their numbers in this assay, from the lowest: compounds 1 and 3 (each within the scatter of the next); then compound 2.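

In this assay, 2-nitrobenzyl in place of benzyl gives no change at the digits printed from compound 1 to compound 3 (within the scatter). Within the data shown here, this is the first reading of a change on the aromatic ring, with nitro ortho to a large group, and the half-life stays level with the phosphorus configuration of compound 1 held fixed, a kind of change the pair of compound 1 and compound 2 did not cover. Nothing at hand bears on a cause for this result.

On these data alone, whether an amine or a carboxylic acid at the same place would also leave the half-life level remains open. Also open, as far as these compounds go, is whether 2-nitrobenzyl would behave the same way on the phosphorus configuration of compound 2.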